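Acetamido for Trifluoromethyl: An Untested Step

A few compounds are considered here, and "the series" means these few. Any claim that something is new, unique, unknown or untested is made for them only; others in the source may bear on it.

Measured compounds:
compound 1, `O=c1ccc(-c2ccc3cn[nH]c3c2)cn1Cc1cccc(C(F)(F)F)c1`, in an assay for inhibition of MAP kinase-interacting serine/threonine-protein kinase 1 (Homo sapiens), read by luminescence and ADP-Glo, with a stated time of 2 h (a higher number here means a weaker inhibitor, a lower number a stronger inhibitor), gives 40 nM
compound 2, `O=c1ccc(-c2ccc3cc[nH]c3c2)cn1Cc1ccccc1`, in this assay gives > 2000 nM

For the measured compounds named here, compound 1 holds the only numerical value in this assay. For compound 2 the result is a limit of the assay rather than a number, and it sits at the limit of > 2000 nM in this assay, at which 1 of the 2 values shown sits. Going by the values given here, no pair of measured compounds differs in a single place, so no measured step is available to calibrate what a change at the benzyl ring does to potency.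

Compound 3, `CC(=O)Nc1cccc(Cn2cc(-c3ccc4cn[nH]c4c3)ccc2=O)c1`, remains to be measured in this assay. It differs from compound 1 by acetamido in place of trifluoromethyl on an aromatic carbon. The group that leaves carries no hydrogen-bond donor or acceptor, while the acetamido that enters carries one of each; beyond that, nothing in the present data indicates how the assay responds to such a swap.

The step from compound 1 to compound 3 is therefore expected to be modest, with a lean toward weaker inhibition, roughly a 2.3-fold higher number from compound 1 to compound 3 (0.35 log units; beyond the scatter). Compound 3 is estimated at 90 nM, between 25 nM and 400 nM.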

Compound 3, half-maximal inhibitory concentration: 163 nM
Estimate against measurement, compound 3: 1.8-fold (0.26 log units) below, within the range that was stated.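

In this assay, acetamido in place of trifluoromethyl on an aromatic carbon, meta to a large group, gives a 4.1-fold higher number from compound 1 to compound 3 (0.61 log units; beyond the scatter). For the compounds shown here, this is the first measured step at this position, and it shows that the position responds to the change, yet the loss is not complete: compound 3 still gives 163 nM, a measured number rather than a limit of the assay. No measurement shown separates the contribution of the hydrogen-bond donor from that of the acceptor that acetamido brings, and nothing shown gives a cause for the step.

From the compounds shown here alone, a single step at a single position sets no trend, so it remains open whether an amine, a carboxylic acid or a methoxy group on the same aromatic carbon would give a number nearer to that of compound 1 or that of compound 3. Compound 2 differs from the other compounds in more than one place and its result is a limit of the assay, which leaves the effect of each of those differences unresolved: the limit of > 2000 nM in this assay, at which 1 of the 3 values shown sits.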